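Notes on the amide side chain: compound 3 to compound 4

The source may report more compounds than this note shows. Statements on the series, on what has been measured and on what is new or still open speak of the compounds shown alone.

In a functional assay on PC-3 cells (Homo sapiens) for antiproliferative activity, read by MTT assay, with a stated time of 24 h (on this read-out lower numbers stand for stronger inhibition and higher numbers for weaker inhibition), compound 1 `CCn1c(C(=O)N[C@H](C)C(=O)OC)ccc1C(CC)(CC)c1ccc(OCS(=O)(=O)c2ccccc2)c(C)c1` gives only a limit of the assay, > 50000 nM. Compound 2 `CCn1c(C(=O)NCCO)ccc1C(CC)(CC)c1ccc(OCS(=O)(=O)c2ccccc2)c(C)c1` gives 17700 nM in this assay, and compound 3 `CCn1c(C(=O)N[C@@H](C)C(=O)O)ccc1C(CC)(CC)c1ccc(OCS(=O)(=O)c2ccccc2)c(C)c1` gives 16800 nM. Compound 3 therefore holds the lower of the two numbers, yet the gap a 1.1-fold lower number from compound 2 to compound 3 (0.02 log units; within the scatter) is within the scatter, so compound 2 and compound 3 are not separated. Against compound 1 the steps of an at least 2.9-fold lower number from compound 1 to compound 3 (0.47 log units; beyond the scatter) and an at least 2.8-fold lower number from compound 1 to compound 2 (0.45 log units; beyond the scatter) are modest and rest on a limit (the limit of > 50000 nM in this assay, at which 1 of the 3 values shown sits).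

Compound 4 `CCn1c(C(=O)N[C@@H](CCC(=O)O)C(=O)O)ccc1C(CC)(CC)c1ccc(OCS(=O)(=O)c2ccccc2)c(C)c1` differs from compound 3 by carboxymethyl in place of hydrogen on a saturated chain carbon, two bonds along the chain from an amide-type nitrogen and a carbonyl carbon. For the measured compounds named here, no measured step adds a group at this chain carbon; the measured amide-side steps changed the end group, not the chain. The expected step of a 1.1-fold lower number from compound 3 to compound 4 (0.05 log units; within the scatter) stays within the scatter. Compound 4 is estimated at 15000 nM, between 6000 nM and 40000 nM.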

Compound 4, half-maximal inhibitory concentration: > 50000 nM
Compound 4 ended at the assay's limit; the forecaster's own chance of this, stated with the estimate: 20%; middle value at least 3.3-fold (0.52 log units) from the limit.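

In this assay a change on the chain itself now moves the read-out toward weaker inhibition: carboxymethyl in place of hydrogen gives an at least 2.9-fold higher number from compound 3 to compound 4 (0.47 log units; beyond the scatter) and 1,3-dicarboxypropyl in place of 2-hydroxyethyl gives an at least 2.8-fold higher number from compound 2 to compound 4 (0.45 log units; beyond the scatter) on the amide-type nitrogen. Both steps are minimum sizes, and the step between compound 1 and compound 4 cannot be read: the limit of > 50000 nM in this assay, at which 2 of the 4 values shown sit.

As far as these compounds go, how far compound 4 lies past its limit stays open. Also open, from the compounds shown here alone, is whether an amine or a primary amide in place of the added carboxylic acid would hold the level of compound 3.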